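Clearance notes on a piperidine amide pair

The source may report more compounds than this note shows. Statements on the series, on what has been measured and on what is new or still open speak of the compounds shown alone.

Measured compounds in an ADME assay on cells (Hepatocyte, Rattus norvegicus) for metabolic stability; a lower number here means slower removal, a higher number faster removal of the compound:
compound 1 `CNC(=O)CN1CCC(c2cc3c(-c4ccc(=O)n(C(C)C)c4)ccnc3[nH]2)CC1` gives 8.9 uL/min
compound 2 `CC(=O)N1CCC(c2cc3c(-c4ccc(=O)n(C(C)C)c4)ccnc3[nH]2)CC1` gives 2.8 uL/min

Going by the values given here, compound 2 stands lowest of the two numbers so far; its nearest neighbour is compound 1, and the one measured step, a 3.2-fold lower number from compound 1 to compound 2 (0.50 log units; beyond the scatter), is modest but beyond the scatter. Compound 3 `CC(C)n1cc(-c2ccnc3[nH]c(C4CCN(CC(=O)N5CCCC5)CC4)cc23)ccc1=O` is not yet measured. It differs from compound 2 in one place: ((pyrrolidin-1-yl)carbonyl)methyl in place of acetyl on an amine nitrogen in a ring. Among the compounds with values here, the only step that bears on this change is the reverse of the one from compound 1 to compound 2, in which the acetyl gave the lower number; the entering group in compound 3 is again a larger amide-bearing chain on the same ring nitrogen, so the number for compound 3 is expected to move upward rather than downward, by about a 2.7-fold higher number from compound 2 to compound 3 (0.43 log units; beyond the scatter). On that basis compound 3 is estimated at 7.5 uL/min, with a range from 3.5 uL/min to 16 uL/min.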

Compound 3, intrinsic clearance in a liver preparation (reported as CLH), per the amount of preparation that the assay uses in the Hepatocyte assay: 5.4 uL/min
The estimate for compound 3 lay 1.4-fold (0.14 log units) above the measured number, within the range that was stated.
By their numbers in the Hepatocyte assay, from the lowest: compounds 2, 3 and 1 (each within the scatter of the next, the first and the last beyond it).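

Going by these compounds alone, in the Hepatocyte assay, ((pyrrolidin-1-yl)carbonyl)methyl in place of acetyl on the amine nitrogen in a ring gives a 1.9-fold higher number from compound 2 to compound 3 (0.29 log units; within the scatter), while pyrrolidin-1-yl in place of methylamino on a carbonyl carbon gives a 1.6-fold lower number from compound 1 to compound 3 (0.22 log units; within the scatter), so compound 3 cannot be separated from either neighbour, although a 3.2-fold lower number from compound 1 to compound 2 (0.50 log units; beyond the scatter) remains the one step beyond the scatter. In a physicochemical assay for lipophilicity, using the shake flask method, measured as octanol-water partition, at pH 7.4 (a higher number here means a more lipophilic compound, a lower number a more polar compound), compound 2 gives 2.1 and compound 3 gives 2.1, which is no change at the digits printed from compound 2 to compound 3 (within the scatter). The data offer no measured basis for explaining these numbers.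

Whether a carboxylic acid or a longer chain on the same ring nitrogen would stay within the scatter of these compounds in the Hepatocyte assay remains open. On these data alone, the effect of a morpholin-4-yl group in place of pyrrolidin-1-yl on the carbonyl carbon is also open.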